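A few compounds are considered here, and "the series" means these few. Any claim that something is new, unique, unknown or untested is made for them only; others in the source may bear on it.

Working notes on the series. Compound 1 `CCC(C)OC(=O)C1=C(C)NC(=O)NC1c1ccoc1` carries sec-butyl on the ester oxygen and furan-3-yl on the saturated ring carbon of the shared core. In an assay on membranes from CHO cells for displacement of a labelled ligand from adenosine receptor A1 (Homo sapiens), read by scintillation counting, with a stated time of 60 min, tested at 1 uM (on this read-out lower numbers stand for less inhibition and higher numbers for more inhibition at the one concentration tested (going by the name of the read-out)), compound 1 gives 13%. Compound 2 `CC1=C(C(=O)OC2CCC2)C(c2ccoc2)NC(=O)N1` differs from compound 1 only in that (cyclobutyl in place of sec-butyl on an oxygen next to a carbonyl group); in this assay compound 2 gives 20%, so this change made a step of a number 7 percentage points higher from compound 1 to compound 2 (within the scatter). Compound 3 `CCC(C)OC(=O)C1=C(C)NC(=O)NC1c1cccs1` differs from compound 1 in the core, in that (thiophen-2-yl in place of furan-3-yl on a saturated ring carbon); in this assay compound 3 gives 5%, a step of a number 8 percentage points lower from compound 1 to compound 3 (within the scatter). Compound 3 and compound 2 are not linked by a single change, and their two numbers lie beyond the scatter of each other.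

Compound 4 `CC1=C(C(=O)OC2CCC2)C(c2cccs2)NC(=O)N1` has not been measured. Among the compounds with values here, it differs from compound 3 in that (cyclobutyl in place of sec-butyl on an oxygen next to a carbonyl group), which is the same change as the one from compound 1 to compound 2, now made on the core of compound 3; the place is described in the same words in both cases, so it is the same change and not merely the same kind. Within the data shown here, the only precedent for it is small, because a number 7 percentage points higher from compound 1 to compound 2 (within the scatter) lies within the scatter. The expected step is therefore a number 7 percentage points higher from compound 3 to compound 4 (within the scatter), set beside the measured a number 7 percentage points higher from compound 1 to compound 2 (within the scatter). In this assay compound 4 is estimated at 12%, with a likely range from -3% to 27%.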

Compound 4, a percentage reported as inhibition, at one concentration (the size of the read-out at that concentration, not a potency): 24%
Compound 4: middle estimate off by 12 percentage points, on the low side, and the stated range covers the measured number.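

In this assay, cyclobutyl in place of sec-butyl on an oxygen next to a carbonyl group makes a step of a number 19 percentage points higher from compound 3 to compound 4 (beyond the scatter), and set beside the earlier step, the change carries across the two cores with no difference that can be told from scatter: the same change on two cores in this assay, a number 7 percentage points higher (within the scatter) from compound 1 to compound 2 and a number 19 percentage points higher (beyond the scatter) from compound 3 to compound 4, 12 percentage points apart, within the scatter of two such steps. The other change closing this square, thiophen-2-yl in place of furan-3-yl on a saturated ring carbon, makes a step of a number 4 percentage points higher from compound 2 to compound 4 (within the scatter), and it too reads alike in both settings: the same change on two cores in this assay, a number 8 percentage points lower (within the scatter) from compound 1 to compound 3 and a number 4 percentage points higher (within the scatter) from compound 2 to compound 4, 12 percentage points apart, within the scatter of two such steps. This shows agreement within scatter on one square of four compounds only; it does not show that the change adds a fixed amount on any core, as one of its two steps lies within the scatter and the other beyond it, and every number is an inhibition read at one concentration, not a potency.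

From the compounds shown here alone, whether the same change holds on a third core stays open, as does the behaviour of the series at any other concentration. Also open, going by these compounds, is what a longer chain, such as n-hexyl, or a chain ending in an amine would give on an oxygen next to a carbonyl group, in place of sec-butyl or cyclobutyl.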